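Swapping a pyridine for a pyrazine on the shared core

The compounds below may be only part of what the source reports. "The series", "measured", "known", "first", "only" and "open" are said of these compounds alone.

Compound 1 `COc1ccccc1-c1cn(C(=O)NCCCCc2ccccc2)c(=O)o1`: 177 nM in an assay on isolated protein for inhibition of acid ceramidase (Homo sapiens), read by LC-MS, with a stated time of 1 h; on this read-out higher numbers stand for weaker inhibition and lower numbers for stronger inhibition
Compound 2 `O=C(NCCCCc1ccccc1)n1cc(-c2cccnc2)oc1=O`: 70 nM
Compound 3 `O=C(NCCCCc1ccccc1)n1cc(-c2ccncc2)oc1=O`: 18 nM

Compound 3 gives the lowest number of the three and is the strongest inhibitor here: the step of a 3.9-fold lower number from compound 2 to compound 3 (0.59 log units; beyond the scatter) and the step of a 9.8-fold lower number from compound 1 to compound 3 (0.99 log units; beyond the scatter) both lie beyond the scatter. Compound 4 `O=C(NCCCCc1ccccc1)n1cc(-c2cnccn2)oc1=O` arises from compound 3 by pyrazin-2-yl in place of pyridin-4-yl on an aromatic carbon. Among the compounds with values here, no measured step replaces a six-membered ring with one nitrogen by one with two, so the guides are indirect. The step of a 3.9-fold lower number from compound 2 to compound 3 (0.59 log units; beyond the scatter) shows that merely moving the single ring nitrogen shifts the number well beyond the scatter, and the step of a 2.5-fold lower number from compound 1 to compound 2 (0.40 log units; beyond the scatter) shows a smaller shift from a different ring. Because pyrazin-2-yl is neither of the two measured pyridines and compound 3 already gives 18 nM, a modest move toward a higher number is expected, estimated as a 2.8-fold higher number from compound 3 to compound 4 (0.44 log units; beyond the scatter). For compound 4 the expected value is 50 nM, with a range from 15 nM to 160 nM.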

Compound 4, half-maximal inhibitory concentration in the acid ceramidase assay: 32 nM
Estimate against measurement, compound 4: 1.6-fold (0.19 log units) above; the range from low to high includes it.
By their numbers in the acid ceramidase assay, from the lowest: compounds 3 and 4 (each within the scatter of the next); then compound 2; then compound 1.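

In the acid ceramidase assay the change to pyrazin-2-yl gives a 1.8-fold higher number from compound 3 to compound 4 (0.25 log units; within the scatter), so this pair cannot be told apart. In the acid ceramidase assay the same ring still stands clear of the other two groups at this place, with a 2.2-fold lower number from compound 2 to compound 4 (0.34 log units; beyond the scatter) and with a 5.5-fold lower number from compound 1 to compound 4 (0.74 log units; beyond the scatter). A six-membered aromatic ring with 2 hetero atoms is therefore accepted on this aromatic carbon next to the ring oxygen, which the single-nitrogen pyridines could not show.

In a physicochemical assay for solubility, read by HPLC, in phosphate buffer, measured as kinetic solubility, with a stated time of 1 h, at pH 7.4, tested at 250 uM (a lower number here means a less soluble compound, a higher number a more soluble compound), compound 3 gives < 1000 nM, which is a limit of the assay and not a number. In the physicochemical assay compound 4 gives < 1000 nM, which is likewise a limit of the assay and not a number. In the physicochemical assay the step from compound 3 to compound 4 cannot be read, as both values are limits and not numbers: the limit of < 1000 nM in the physicochemical assay, at which 2 of the 2 values shown sit. As far as these compounds go, what a pyrimidin-4-yl ring, or an amine added to the pyrazin-2-yl ring, would do at this place remains open.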